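The source may hold more compounds than are shown below. What is called first, only, known or untested is meant among the compounds shown, and "the series" means these compounds.

Measured in an ADME assay on microsomes from liver (Homo sapiens) for pharmacokinetics; on this read-out lower numbers stand for slow clearance and higher numbers for fast clearance:
- compound 1 `Cc1c(Nc2nc(N)c3c(C#N)c(N4CCC[C@H]4C)n(C)c3n2)cnn1C`: 41.7 mL/min/kg
- compound 2 `Cc1c(Nc2nc(N)c3c(C#N)c(N4CCC[C@H]4C)n(C)c3n2)cnn1[C@H]1CCOC1`: 23.3 mL/min/kg
- compound 3 `Cc1nn(C2CCOC2)cc1Nc1nc(N)c2c(C#N)c(N3CCC[C@H]3C)n(C)c2n1`: 76.7 mL/min/kg; 200 mL/min/kg (2 entries)

In this assay, compound 2 sits at 23.3 mL/min/kg, and the comparison with its nearest neighbour shows a 1.8-fold lower number from compound 1 to compound 2 (0.25 log units; within the scatter). Its number therefore cannot be separated from that of compound 1. Compound 3 also carries an oxolan-3-yl group, but it offers no single number for comparison, as its repeated entries show: the several entries of compound 3 in this assay, 76.7 mL/min/kg; 200 mL/min/kg (2 entries).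

The next compound to be tested is compound 4 `Cc1c(Nc2nc(N)c3c(C#N)c(N4CCC[C@H]4C)n(C)c3n2)cnn1CC1(O)COC1`, which has (3-hydroxyoxetan-3-yl)methyl in place of oxolan-3-yl on an aromatic nitrogen. The rest of the molecule stays the same, so any change in clearance would trace back to this one group.

Going by the values given here, only one measured step bears directly on this nitrogen, the exchange of methyl for oxolan-3-yl, and its size was a 1.8-fold lower number from compound 1 to compound 2 (0.25 log units; within the scatter). That step gives no support for expecting a large shift from a further exchange at the same place. The expected change is a 1.2-fold lower number from compound 2 to compound 4 (0.07 log units; within the scatter), which is estimated to stay within the scatter. For compound 4 the estimated clearance is 20 mL/min/kg, with an expected range of 9 mL/min/kg to 42 mL/min/kg.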

Compound 4, clearance: 35 mL/min/kg
For compound 4 the middle estimate is 1.8-fold (0.24 log units) below the measured one, within the range that was stated.
By their numbers in this assay, from the lowest: compounds 2, 4 and 1 (each within the scatter of the next).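

In this assay, the aromatic nitrogen now carries a third kind of group: (3-hydroxyoxetan-3-yl)methyl has a four-membered ring and a hydrogen-bond donor, whereas oxolan-3-yl has a five-membered ring and no donor. Even so, this exchange gives a 1.5-fold higher number from compound 2 to compound 4 (0.18 log units; within the scatter), and adding 3-hydroxyoxetan-3-yl to the methyl group gives a 1.2-fold lower number from compound 1 to compound 4 (0.08 log units; within the scatter), so methyl, oxolan-3-yl and (3-hydroxyoxetan-3-yl)methyl cannot be told apart at this nitrogen, and none of the three steps among them leaves the scatter. Small gaps like these have to be read with caution, as one compound measured more than once shows how far entries in this assay can spread: the several entries of compound 3 in this assay, 76.7 mL/min/kg; 200 mL/min/kg (2 entries)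

Going by these compounds, whether any group at this nitrogen can move clearance beyond the scatter remains open, for example a carboxylic acid or a longer chain ending in an amine. The compounds shown also leave open whether the other mirror-image form of oxolan-3-yl would give a number that can be separated from that of compound 2.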